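Tolerated Concentration Across a Small Aryl Series

The source may hold more compounds than are shown below. What is called first, only, known or untested is meant among the compounds shown, and "the series" means these compounds.

Measured so far in an ADME assay on RAW264.7 cells (Mus musculus) for cytotoxicity, read by MTT assay, with a stated time of 48 h; a lower number here means that less compound is tolerated, a higher number that more compound is tolerated:
compound 1 `CC(=O)OC[C@H]1O[C@H](OC[C@@H](Cn2cc(CN(c3nc(-c4cccc([N+](=O)[O-])c4)no3)C3CCCCC3)nn2)OC(C)=O)C=C[C@@H]1OC(C)=O` gives 100 ug/mL
compound 2 `CC(=O)OC[C@H]1O[C@H](OC[C@@H](Cn2cc(CN(c3nc(-c4ccc(C)cc4)no3)C3CCCCC3)nn2)OC(C)=O)C=C[C@@H]1OC(C)=O` gives 45.3 ug/mL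
compound 3 `CC(=O)OC[C@H]1O[C@H](OC[C@@H](Cn2cc(CN(c3nc(-c4cccc(C)c4)no3)C3CCCCC3)nn2)OC(C)=O)C=C[C@@H]1OC(C)=O` gives 46.4 ug/mL

Compound 3 stands second highest of the three numbers in this assay. Its value and that of compound 2 lie within the scatter of each other, while compound 1 sits apart from it by the step of a 2.2-fold lower number from compound 1 to compound 3 (0.33 log units; beyond the scatter).

Compound 4 `CC(=O)OC[C@H]1O[C@H](OC[C@@H](Cn2cc(CN(c3nc(-c4ccc(Br)cc4)no3)C3CCCCC3)nn2)OC(C)=O)C=C[C@@H]1OC(C)=O` differs from compound 3 in one place: 4-bromophenyl in place of 3-methylphenyl on an aromatic carbon.

Two of the measured steps bear on a change of the substituent on the phenyl ring: a 2.2-fold lower number from compound 1 to compound 2 (0.34 log units; beyond the scatter) and a 2.2-fold lower number from compound 1 to compound 3 (0.33 log units; beyond the scatter), both modest. The third, a 1.0-fold higher number from compound 2 to compound 3 (0.01 log units; within the scatter), shows that shifting the methyl from the 4- to the 3-position of the phenyl ring made no difference beyond the scatter. Within the data shown here, no compound carrying bromine has been measured, so the direction of the step to compound 4 cannot be anchored; the expected step is small, a 1.1-fold higher number from compound 3 to compound 4 (0.03 log units; within the scatter). Compound 4 is therefore estimated at 50 ug/mL in this assay, with a range from 25 ug/mL to 100 ug/mL.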

Compound 4, half-maximal cytotoxic concentration: 39.1 ug/mL
Compound 4: middle estimate off by 1.3-fold (0.11 log units), on the high side, within the range that was stated.
By their numbers in this assay, from the lowest: compounds 4, 2 and 3 (each within the scatter of the next); then compound 1.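

In this assay, 4-bromophenyl in place of 3-methylphenyl on the carbon between two ring nitrogen atoms stays within the scatter (a 1.2-fold lower number from compound 3 to compound 4 (0.07 log units; within the scatter)), and bromo in place of methyl at the same 4-position of the phenyl ring does too (a 1.2-fold lower number from compound 2 to compound 4 (0.06 log units; within the scatter)). Bromine thus joins the two methyl compounds in a single group, so among compounds 2, 3 and 4 neither the choice of these substituents nor the methyl position separates the numbers, while the 3-nitrophenyl of compound 1 still stands apart (a 2.6-fold lower number from compound 1 to compound 4 (0.41 log units; beyond the scatter)). Nothing at hand explains these numbers.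

On these data alone, it remains open whether the separation of compound 1 belongs to the nitro group alone or to nitro at the 3-position, as a 4-nitrophenyl would show. As far as these compounds go, how an amine or a carboxylic acid on the phenyl ring would compare also remains open.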